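This account rests on a few compounds, and the source may have more. Where it says the series, first, only, none or still open, it means among the compounds named here.

Measured so far in a functional assay on MIA PaCa-2 cells (Homo sapiens) for inhibition, read by MTT assay, with a stated time of 72 h; on this read-out higher numbers stand for weaker inhibition and lower numbers for stronger inhibition:

- Compound 1, `COc1cc(NC(C)CCCNC(=O)NNC(=O)Nc2cc(C(F)(F)F)cc(C(F)(F)F)c2)c2ncccc2c1`, gives 20000 nM.
- Compound 2, `COc1cc(NC(C)CCCNC(=O)NNC(=O)Nc2ccc(Br)cc2)c2ncccc2c1`, gives 231000 nM.
- Compound 3, `COc1cc(NC(C)CCCNC(=O)Nc2ccc(O)cc2)c2ncccc2c1`, gives 57000 nM.

Compound 3 sits second highest of the three numbers, with compound 1 nearest and compound 2 furthest away. All three share the same core and differ only in the group on the amide-type nitrogen at the end of the chain.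

Compound 4, `COc1cc(NC(C)CCCNC(=O)NNC(=O)Nc2ccc(F)cc2)c2ncccc2c1`, has not yet been measured. It differs from compound 3 in one place: ((4-fluorophenyl)carbamoyl)amino in place of 4-hydroxyphenyl on an amide-type nitrogen.

Going by the values given here, one measured step bears on this directly, and it runs the other way: a 4.1-fold lower number from compound 2 to compound 3 (0.61 log units; beyond the scatter). Compound 4 partly undoes that change, restoring a carbamoylamino linker to a substituted phenyl ring, though the fluorine here is a different substituent from the bromine of compound 2. The values of compound 1 and compound 2 show that the substituent on that distal ring can shift the number substantially, so the size of the reversal is uncertain.

On this basis a modest rise in the number from compound 3 to compound 4 is expected, a 1.9-fold higher number from compound 3 to compound 4 (0.29 log units; within the scatter), and the estimate for compound 4 in this assay is 110000 nM, with a range from 30000 nM to 350000 nM.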

Compound 4, half-maximal inhibitory concentration: >= 250000 nM
Compound 4 gave a limit, no number; the forecaster's own chance of this, stated with the estimate: 10%; middle value at least 2.2-fold (0.35 log units) away from the limit.
By their numbers in this assay, from the lowest: compound 1; then compound 3; then compound 2. At a limit, above all of these: compound 4.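

In this assay compound 4 gives a limit rather than a number: the limit of >= 250000 nM in this assay, at which 1 of the 4 values shown sits. Putting ((4-fluorophenyl)carbamoyl)amino in place of 4-hydroxyphenyl on the amide-type nitrogen gives an at least 4.3-fold higher number from compound 3 to compound 4 (0.64 log units; beyond the scatter), so this second carbamoylamino compound, like compound 2, stands on the weaker side of compound 3, while compound 1 goes against that trend with 20000 nM. Fluoro in place of bromo on the aromatic carbon gives an at least 1.0-fold higher number from compound 2 to compound 4 (0.03 log units; that floor lies within the scatter), and since that floor lies within the scatter, the limit does not order these two halogens, though it does show that swapping bromo for fluoro brings no visible gain on this read-out.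

On these data alone, the true number of compound 4 stays unknown, so the size of any difference between fluoro and bromo remains open. Also open, as far as these compounds go, is how the number would move with an amine or a carboxylic acid on the ring in place of the hydroxyl of compound 3, or with a longer chain between the shared core and the amide-type nitrogen.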